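The source may report more compounds than this note shows. Statements on the series, on what has been measured and on what is new or still open speak of the compounds shown alone.

In a functional assay on A549 cells (Homo sapiens) for cytotoxicity, read by MTT assay, with a stated time of 48 h (a lower number here means a stronger inhibitor, a higher number a weaker inhibitor), compound 1 `COc1cc(COCc2cn(Cc3cc(C)cnc3Cl)nn2)cc(OC)c1OC` gives 41900 nM. Compound 3 `COc1cc(COCc2cn(Cc3cc(-c4ccc(F)cc4)cnc3Cl)nn2)cc(OC)c1OC` differs from compound 1 in one place, (4-fluorophenyl in place of methyl on an aromatic carbon), and in this assay compound 3 gives 50600 nM; that single change made the step of a 1.2-fold higher number from compound 1 to compound 3 (0.08 log units; within the scatter). Compound 2 `COc1cc(-c2cc(COCc3cn(Cc4cc(C)cnc4Cl)nn3)on2)cc(OC)c1OC` is built on a different core, and the difference between the two cores is not broken down here. In this assay compound 2 gives 256000 nM, the highest of the three numbers measured. Compound 4 `COc1cc(-c2cc(COCc3cn(Cc4cc(-c5ccc(F)cc5)cnc4Cl)nn3)on2)cc(OC)c1OC` carries the same change made on compound 2, namely (4-fluorophenyl in place of methyl on an aromatic carbon). The step is expected to be a 1.2-fold higher number from compound 2 to compound 4 (0.07 log units; within the scatter), about as small as the earlier one, because a 1.2-fold higher number from compound 1 to compound 3 (0.08 log units; within the scatter) stayed within the scatter. Compound 4 is therefore estimated at 300000 nM, with a likely range from 140000 nM to 650000 nM.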

Compound 4, half-maximal inhibitory concentration: 40600 nM
Compound 4: the middle estimate sits 7.4-fold (0.87 log units) above what was measured; measured number outside the range, below it.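

Putting 4-fluorophenyl in place of methyl on an aromatic carbon did not act alike on the two cores, and in this assay the step on the second core is a 6.3-fold lower number from compound 2 to compound 4 (0.80 log units; beyond the scatter), so the result on one core did not carry over to the other: the same change on two cores in this assay, a 1.2-fold higher number (0.08 log units; within the scatter) from compound 1 to compound 3 and a 6.3-fold lower number (0.80 log units; beyond the scatter) from compound 2 to compound 4, 7.6-fold (0.88 log units) apart, beyond the scatter of two such steps.
The effect of this change therefore depends on the core that carries it, at least for these two pairs of compounds. For the compounds shown here, with only one pair on each core, this does not show why the cores differ, or whether any other change would behave the same way.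

The compounds shown leave open what an amine, a carboxylic acid or a longer carbon chain on that same aromatic carbon would do on either core. They also leave open whether such groups would split the two cores in the same way.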